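The compounds below may be only part of what the source reports. "The series", "measured", "known", "first", "only" and "open" are said of these compounds alone.

Of the compounds shown here, three have so far been measured in an ADME assay on microsomes from liver (Homo sapiens) for metabolic stability, read by LC-MS, using NADPH, with stated times of 5 min and 30 min, tested at 1 uM; a lower number here means slower removal, a higher number faster removal of the compound. Compound 1 `Cc1ncccc1-c1cnc(NCc2c(F)ccc3c2CCO3)c2nn(CC#N)c(=O)n12` gives 151 mL.min-1.g-1 in this assay. Compound 2 `O=C1CCCN1c1cnc(NCc2c(F)ccc3c2CCO3)c2cn[nH]c(=O)c12` gives 23 mL.min-1.g-1 in this assay, the lower of the two numbers reported; the nearest number is that of compound 1, which stands higher by a gap beyond the usual scatter. Compound 3 `O=C(Nc1cnc(NCc2c(F)ccc3c2CCO3)n2cnnc12)c1cccnc1` returns only a limit in this assay, < 3 mL.min-1.g-1, and no number. That result is the limit of < 3 mL.min-1.g-1 in this assay, at which 1 of the 3 values shown sits.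

Compound 4 `CNC(=O)c1ccc(-c2cnc(NCc3c(F)ccc4c3CCO4)c3cn[nH]c(=O)c23)c(C)n1` has not yet been measured. It differs from compound 2 in one place: 2-methyl-6-(methylcarbamoyl)pyridin-3-yl in place of 2-oxopyrrolidin-1-yl on an aromatic carbon. The entering group, 2-methyl-6-(methylcarbamoyl)pyridin-3-yl, carries one hydrogen-bond donor and two hydrogen-bond acceptors where the departing 2-oxopyrrolidin-1-yl carried none and one.

Within the data shown here, no pair of measured compounds shows what this exchange does, so the expectation rests on compound 2 alone, whose reading of 23 mL.min-1.g-1 is the starting point. The step of a 1.5-fold higher number from compound 2 to compound 4 (0.18 log units; within the scatter) is expected to be a modest rise, one that need not exceed the scatter of this assay. Compound 4 is therefore estimated to give about 35 mL.min-1.g-1 in this assay, with a plausible range from 12 mL.min-1.g-1 to 100 mL.min-1.g-1.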

Compound 4, intrinsic clearance in microsomes: 23 mL.min-1.g-1
Compound 4: the middle estimate sits 1.5-fold (0.18 log units) above what was measured, within the range that was stated.
By their numbers in this assay, from the lowest: compounds 2 and 4 (each within the scatter of the next); then compound 1. At a limit, below all of these: compound 3.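

In this assay, among these compounds, the exchange of 2-oxopyrrolidin-1-yl for 2-methyl-6-(methylcarbamoyl)pyridin-3-yl on an aromatic carbon gives the first step between compounds that differ in one place, and it reads no change at the digits printed from compound 2 to compound 4 (within the scatter). This position of the shared core can therefore carry a six-membered aromatic ring with a hydrogen-bond donor in its substituent, in place of a five-membered non-aromatic ring without one, and the clearance reading stays within the scatter, something compound 1 and compound 3 could not show since each differs from compound 2 in more than one place. Nothing measured here bears on why the reading holds across so large an exchange.

The entering group brings its ring, its methyl and its methylcarbamoyl all at once, so the contribution of each part remains unread. Also open, going by these compounds, are how a plain phenyl, an amine or a carboxylic acid on this aromatic carbon would read, and whether the same exchange would behave alike on the core of compound 1 or of compound 3.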